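1H-tetrazol-1-yl for dimethylsulfamoyl: working notes

The compounds below may be only part of what the source reports. "The series", "measured", "known", "first", "only" and "open" are said of these compounds alone.

In a physicochemical assay for lipophilicity, using the shake flask method, in phosphate buffer, measured as octanol-water partition, at pH 7.4 (a higher number here means a more lipophilic compound, a lower number a more polar compound), compound 1 `CC(C)(C)OC(=O)N1CCN(c2ncc(OCc3ccc(S(C)(=O)=O)cc3)nn2)CC1` gives 2.9. In this assay compound 2 `C[C@@H]1CN(C(=O)OC(C)(C)C)CCN1c1ncc(OCc2ccc(S(=O)(=O)N(C)C)cc2)cn1` gives > 4.3, which is a limit and not a number. Compound 3 `C[C@@H]1CN(C(=O)OC(C)(C)C)CCN1c1ncc(OCc2ccc(-n3cnnn3)cc2)cn1` has 1H-tetrazol-1-yl in place of dimethylsulfamoyl on an aromatic carbon, para to a large group: 1H-tetrazol-1-yl in place of dimethylsulfamoyl on an aromatic carbon. Within the data shown here, no measured pair isolates this change, so the expectation rests on the structural change alone. A fall in this assay beyond the scatter is expected, with an estimated step of a number at least 0.50 log units lower from compound 2 to compound 3 (beyond the scatter). For compound 3 the estimated value is 3.8, with an expected range of 3.2 to 4.3.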

Compound 3, distribution coefficient: > 4.3
Compound 3: a limit, no number (the forecaster's own chance of this, stated with the estimate: 15%); at least 0.50 log units between middle value and limit.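

In this assay no step from compound 2 to compound 3 can be read, because both results are limits and not numbers: the limit of > 4.3 in this assay, at which 2 of the 3 values shown sit.

Whether 1H-tetrazol-1-yl in place of dimethylsulfamoyl shifts this read-out at all, and in which direction, stays open with the compounds shown.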